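Para-halogen swap in an acyl thiourea series

This account rests on a few compounds, and the source may have more. Where it says the series, first, only, none or still open, it means among the compounds named here.

Compound 1 `O=C(NC(=S)N1CCc2c(OCCCCCOc3ccc(Cl)cc3)cccc21)c1ccc([N+](=O)[O-])cc1` — an ADME assay on Huh-7 cells (Homo sapiens) for cytotoxicity; on this read-out lower numbers stand for higher toxicity in this test and higher numbers for lower toxicity in this test: 13600 nM
Compound 2 `N#Cc1ccc(C(=O)NC(=S)N2CCc3c(OCCCCCOc4ccc(Cl)cc4)cccc32)cc1` — a value in this assay that is a limit of the assay: > 50000 nM
Compound 3 `O=C(NC(=S)N1CCc2c(OCCCCCOc3ccc(Cl)cc3)cccc21)c1ccc(F)cc1` — this assay: 31100 nM

Among the two numbers given, compound 3 holds the higher one; the step of a 2.3-fold higher number from compound 1 to compound 3 (0.36 log units; beyond the scatter) separates it from compound 1. The value of compound 2 is a limit only, at the limit of > 50000 nM in this assay, at which 1 of the 3 values shown sits, so its distance to compound 3 is not a number, and the step of an at least 1.6-fold lower number from compound 2 to compound 3 (0.20 log units; that floor lies within the scatter) has a floor that sits within the scatter.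

Compound 4 `O=C(NC(=S)N1CCc2c(OCCCCCOc3ccc(Cl)cc3)cccc21)c1ccc(Br)cc1` differs from compound 3 in one place: bromo in place of fluoro on an aromatic carbon. Going by the values given here, no measured step exchanges one halogen for another, so only the steps of a 2.3-fold higher number from compound 1 to compound 3 (0.36 log units; beyond the scatter) and an at least 3.6-fold higher number from compound 1 to compound 2 (0.56 log units; beyond the scatter) at the same position speak here, and they show that changes at this place have moved the number by modest amounts. A step near the scatter is expected, as a 1.1-fold lower number from compound 3 to compound 4 (0.05 log units; within the scatter). Compound 4 is thus estimated at 28000 nM, within 11000 nM to 50000 nM.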

Compound 4, half-maximal cytotoxic concentration: 29100 nM
Estimate against measurement, compound 4: 1.0-fold (0.02 log units) below; the range from low to high includes it.
By their numbers in this assay, from the lowest: compound 1; then compounds 4 and 3 (each within the scatter of the next). At a limit, above all of these: compound 2.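

In this assay, going by these compounds alone, the step of a 1.1-fold lower number from compound 3 to compound 4 (0.03 log units; within the scatter) is the first exchange of one halogen for another at this place on the ring, and it stays within the scatter. Bromo also stands apart from nitro, with the step of a 2.1-fold higher number from compound 1 to compound 4 (0.33 log units; beyond the scatter), much as fluoro does with the step of a 2.3-fold higher number from compound 1 to compound 3 (0.36 log units; beyond the scatter), so both halogens part from nitro by a modest amount in the same direction. The step of an at least 1.7-fold lower number from compound 2 to compound 4 (0.23 log units; that floor lies within the scatter) gives only a floor that lies within the scatter, so whether bromo and the nitrile differ cannot be read, the nitrile's value being a limit of the assay: the limit of > 50000 nM in this assay, at which 1 of the 4 values shown sits.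

The compounds shown leave open whether chloro or iodo would fall with fluoro and bromo, and whether an amine or a carboxylic acid at this place would stay with the halogens. They also leave open whether the halogen exchange would stay as small with a shorter chain on the shared core.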